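Urea chain length in the iodophenyl sulfonate series

This account rests on a few compounds, and the source may have more. Where it says the series, first, only, none or still open, it means among the compounds named here.

Measured so far:
compound 1 `CC(C)(C)C(=O)Nc1ccc(S(=O)(=O)Oc2ccccc2I)cc1`: 6600 nM
compound 2 `CCNC(=O)Nc1ccc(S(=O)(=O)Oc2ccccc2I)cc1`: 1100 nM

The two measured compounds share the iodophenyl sulfonate core and differ only at the carbonyl carbon. In a functional assay on MCF7 cells (Homo sapiens) for antiproliferative activity, read by sulforhodamine B assay, with a stated time of 48 h (on this read-out higher numbers stand for weaker inhibition and lower numbers for stronger inhibition), compound 1 gives 6600 nM, and compound 2 gives 1100 nM. The step of a 6.0-fold lower number from compound 1 to compound 2 (0.78 log units; beyond the scatter) is the only one in hand. Compound 2 therefore stands with the lowest number of the two, its nearest neighbour being compound 1, which reads higher by that same step.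

Compound 3 `CCCNC(=O)Nc1ccc(S(=O)(=O)Oc2ccccc2I)cc1` carries the change (methyl in place of hydrogen on a saturated chain carbon, two bonds along the chain from an amide-type nitrogen), which read one bond further out is ethylamino to propylamino. For the measured compounds named here, no measured pair shows the effect of lengthening this chain; the only measured step concerns the exchange of tert-butyl for ethylamino and does not bear on a single-carbon extension of the urea substituent. Going by the values given here, with no relevant precedent, the expectation for compound 3 in this assay is a step of about a 1.1-fold lower number from compound 2 to compound 3 (0.04 log units; within the scatter), that is none beyond the scatter. Compound 3 is accordingly estimated at 1000 nM, with a range from 400 nM to 2800 nM.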

Compound 3, half-maximal inhibitory concentration: 2900 nM
Compound 3: middle estimate off by 2.9-fold (0.46 log units), on the low side, and the stated range ends below it.
By their numbers in this assay, from the lowest: compound 2; then compound 3; then compound 1.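

Working notes: in this assay the single-carbon extension from ethylamino to propylamino is not neutral, since it gives a 2.6-fold higher number from compound 2 to compound 3 (0.42 log units; beyond the scatter) and thus shows that this saturated chain carbon, two bonds along the chain from an amide-type nitrogen, responds to an added methyl. Propylamino still compares favourably with tert-butyl on the carbonyl carbon, with a 2.3-fold lower number from compound 1 to compound 3 (0.36 log units; beyond the scatter) against the earlier 6.0-fold lower number from compound 1 to compound 2 (0.78 log units; beyond the scatter) for ethylamino, so compound 2 holds the lowest number of the three and compound 3 sits between compound 2 and compound 1. Nothing available accounts for the change seen at this chain position.

Going by these compounds, a single extension fixes no trend, so it remains open whether a butylamino or longer chain would continue this direction, or whether a methylamino group at the shorter end would read lower still than compound 2. Also open, on these data alone, is how a branched isopropylamino group, a cyclopropylamino group or a chain ending in a hydroxyl group, an amine or a carboxylic acid would read at this position.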